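Quinolin-8-yl exchanged on the carbonyl carbon: outlook for compound 4

A few compounds are considered here, and "the series" means these few. Any claim that something is new, unique, unknown or untested is made for them only; others in the source may bear on it.

Three compounds of the series have numbers in a functional assay on the whole organism (blood) with Rattus norvegicus as the target, with stated times of 24 h and 1 h, at a dose of 5 mg/kg by the intraperitoneal route; a lower number here means a weaker effect, a higher number a stronger effect of the compound at the dose given. Compound 1 `Cc1ncccc1C(=O)NCCC1CCN(S(=O)(=O)NC(=O)NC[C@@H]2C[C@@H]3C=C[C@@H]2C3)CC1` gives 16% in this assay. Compound 2 `COc1ccc2nccc(C(=O)NCCC3CCN(S(=O)(=O)NC(=O)NC[C@@H]4C[C@@H]5C=C[C@@H]4C5)CC3)c2c1` gives 10% in this assay, and the step of a number 6 percentage points lower from compound 1 to compound 2 (within the scatter) lies within the scatter. Compound 3 `O=C(NC[C@@H]1C[C@@H]2C=C[C@@H]1C2)NS(=O)(=O)N1CCC(CCNC(=O)c2cccc3cccnc23)CC1` gives 34% in this assay and stands highest of the three; both steps towards it, a number 18 percentage points higher from compound 1 to compound 3 (beyond the scatter) and a number 24 percentage points higher from compound 2 to compound 3 (beyond the scatter), are beyond the scatter, so compound 3 is the most active of the measured compounds.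

Compound 4 `Cn1cc(C(=O)NCCC2CCN(S(=O)(=O)NC(=O)NC[C@@H]3C[C@@H]4C=C[C@@H]3C4)CC2)c(=O)n(C)c1=O` has not yet been measured in this assay. It differs from compound 3 in one place: a group of 10 heavy atoms (6 carbon, 2 nitrogen, 2 oxygen; one six-membered aromatic ring with 2 hetero atoms) in place of a group of 10 heavy atoms (9 carbon, 1 nitrogen; one six-membered aromatic ring of carbon only, one six-membered aromatic ring with 1 hetero atom), on a carbonyl carbon.

The two steps that bear on this change are the ones into compound 3, since each of them replaced a group on the same carbonyl carbon by quinolin-8-yl and each raised the number modestly. Compound 4 removes quinolin-8-yl again, and the two groups that previously stood in its place gave the numbers of compound 1 and compound 2. For compound 4 a decrease of about that size is therefore expected, back into the range of those two compounds. Compound 4 is expected to give 14% in this assay, within 4% to 28%. The expected step of a number 20 percentage points lower from compound 3 to compound 4 (beyond the scatter) is a decrease beyond the scatter.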

Compound 4, a percentage reported as activity, at one dose (the size of the read-out at that dose, not a potency): 23%
Beside the measured number, compound 4's estimate is 9 percentage points below it; the range from low to high includes it.
By their numbers in this assay, from the lowest: compounds 2, 1 and 4 (each within the scatter of the next, the first and the last beyond it); then compound 3.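

In this assay, quinolin-8-yl on this carbonyl carbon gives way to a group with the same count of 10 heavy atoms but 4 hydrogen-bond acceptors in place of 1, and the result is a number 11 percentage points lower from compound 3 to compound 4 (beyond the scatter), so the heavy-atom count alone does not set the number at this position. Against the earlier groups the picture is mixed, with a number 13 percentage points higher from compound 2 to compound 4 (beyond the scatter) and a number 7 percentage points higher from compound 1 to compound 4 (within the scatter); the number of aromatic rings does not order the series either, since compound 3 and compound 2, each with two such rings, lie on opposite sides of compound 4, which has one. Nothing available on these compounds accounts for the differences in the numbers.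

The compounds shown leave open how a plain phenyl ring or a saturated cyclohexyl ring would read on the same carbonyl carbon, and whether an amine or a carboxylic acid carried on the ring would move the number in either direction. All the numbers come from a single dose, so they leave open whether the order of compound 2, compound 3 and compound 4 would hold at other doses.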